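Stereoisomers of an orexin receptor type 2 agonist series

The source may hold more compounds than are shown below. What is called first, only, known or untested is meant among the compounds shown, and "the series" means these compounds.

Measured so far:
compound 1, `CCS(=O)(=O)NC1CCCN(C(C)=O)C1COC1CCC(C(C)C)CC1`, 570 nM in a functional assay on CHO-K1 cells for agonist activity at Orexin receptor type 2 (Homo sapiens), read by FLIPR and calcium flux; a higher number here means that more compound is needed for the effect, a lower number that less compound is needed
compound 2, `CCS(=O)(=O)N[C@@H]1CCCN(C(C)=O)[C@H]1CO[C@H]1CC[C@@H](C(C)C)CC1`, > 30000 nM

Compound 2 sits at a limit of this assay, so only a bound is known for it. The step of an at least 52-fold higher number from compound 1 to compound 2 (1.72 log units; beyond the scatter) is large; it rests on the limit of > 30000 nM in this assay, at which 1 of the 2 values shown sits, and on (the fact that one of compounds 1 and 2 is drawn with a defined configuration and the other without, at the place where they differ). Compound 3, `CCS(=O)(=O)N[C@H]1CCCN(C(C)=O)[C@H]1CO[C@H]1CC[C@H](C(C)C)CC1`, differs from compound 2 only as drawn: the two compounds have the same atoms and bonds and differ only in configuration as drawn: 3 of 4 stereo elements differ; a stereocentre at a saturated ring carbon is drawn R in compound 2 and S in compound 3; a stereocentre at a saturated ring carbon is drawn s in compound 2 and r in compound 3; a stereocentre at a saturated ring carbon is drawn S in compound 2 and R in compound 3. Within the data shown here, no measured step compares two fully drawn stereoisomers, so the direction of the change is open; the value of compound 1 in this assay shows that some isomer drawn within it is active. For compound 3 a step of an at least 20-fold lower number from compound 2 to compound 3 (1.30 log units; beyond the scatter) is expected, and its value in this assay is estimated at 1500 nM, with a range from 150 nM to 30000 nM.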

Compound 3, half-maximal effective concentration: > 30000 nM
Compound 3: only a limit was reported (the forecaster's own chance of this, stated with the estimate: 30%); middle value at least 20-fold (1.30 log units) from the limit.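

In this assay compound 3 gives > 30000 nM, which is a limit of the assay. A second fully drawn isomer thus ends up with an at least 52-fold higher number from compound 1 to compound 3 (1.72 log units; beyond the scatter), so changing three of the four stereo elements from compound 2 does not recover the activity seen for the undefined drawing: the fact that one of compounds 1 and 3 is drawn with a defined configuration and the other without, at the place where they differ The step between the two limits cannot be read, so no order can be given for this change: the fact that compounds 2 and 3 differ only in the configuration as drawn

Which configuration at the four stereo elements carries the activity of compound 1 stays open. Also open, from the compounds shown here alone, is how a cyclopropyl group in place of the isopropyl would read on the active isomer.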